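The source may hold more compounds than are shown below. What is called first, only, known or untested is meant among the compounds shown, and "the series" means these compounds.

Measured in a functional assay on RT-112 cells (Homo sapiens) for antiproliferative activity, read by MTT assay, with a stated time of 72 h; on this read-out lower numbers stand for stronger inhibition of growth and higher numbers for weaker inhibition of growth:
Compound 1 `COc1cc(Nc2ncnc3c(NC(=O)Nc4cc(Cl)cc(Cl)c4)cccc23)cc(OC)c1`: 30.2 nM.
Compound 2 `COc1cc(Nc2ncnc3c(NC(=O)Nc4ccc([N+](=O)[O-])cc4)cccc23)cc(OC)c1`: > 20000 nM, which is a limit of the assay and not a number.
Compound 3 `COc1cc(Nc2ncnc3c(NC(=O)Nc4ccc5c(c4)OCCO5)cccc23)cc(OC)c1`: 2750 nM.

Compound 3, at 2750 nM, has the higher of the two true numbers, and the gap to the other is large: a 91-fold higher number from compound 1 to compound 3 (1.96 log units; beyond the scatter). The next analogue, compound 4 `COc1cc(Nc2ncnc3c(NC(=O)Nc4ccc(Cl)c(Cl)c4)cccc23)cc(OC)c1`, carries 3,4-dichlorophenyl in place of 2,3-dihydro-1,4-benzodioxin-6-yl on an amide-type nitrogen.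

The closest guide is the step just given, since compound 1 also carries a dichlorophenyl group, there as 3,5-dichlorophenyl. The other measured steps, an at least 660-fold higher number from compound 1 to compound 2 (2.82 log units; beyond the scatter) and an at least 7.2-fold lower number from compound 2 to compound 3 (0.86 log units; beyond the scatter), show that this group can move the number widely. Within the data shown here, no measured step compares the two dichlorophenyl patterns, so recovery of the full gap cannot be assumed. A large step to a lower number is expected, somewhat short of the level of compound 1 at 30.2 nM. The expected change is a 23-fold lower number from compound 3 to compound 4 (1.36 log units; beyond the scatter). For compound 4 the estimated value is 120 nM, with an expected range of 25 nM to 700 nM.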

Compound 4, concentration for 50% growth inhibition: 6230 nM
The estimate for compound 4 lay 52-fold (1.72 log units) below the measured number; measured number outside the range, above it.
By their numbers in this assay, from the lowest: compound 1; then compound 3; then compound 4. At a limit, above all of these: compound 2.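

In this assay, among these compounds, the placement of the two chlorines on the amide-type nitrogen's aryl group matters far more than the earlier compounds could show: a 210-fold higher number from compound 1 to compound 4 (2.31 log units; beyond the scatter), so a dichlorophenyl group alone does not secure the low number of compound 1. The 3,4-dichlorophenyl group also gives no gain over 2,3-dihydro-1,4-benzodioxin-6-yl, with a 2.3-fold higher number from compound 3 to compound 4 (0.36 log units; beyond the scatter), leaving 3,5-dichlorophenyl alone among the groups shown at a low number. The remaining comparison, an at least 3.2-fold lower number from compound 2 to compound 4 (0.50 log units; beyond the scatter), is only a bound, as the value of compound 2 is a limit of the assay and not a number: the limit of > 20000 nM in this assay, at which 1 of the 4 values shown sits.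

From the compounds shown here alone, it remains open whether both chlorines are needed, as a single chlorine in 3-chlorophenyl would test. Also open, going by these compounds, is whether chlorine itself matters, or whether 3,5-dimethylphenyl or 3,5-difluorophenyl would reach the level of compound 1.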